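This account rests on a few compounds, and the source may have more. Where it says the series, first, only, none or still open, it means among the compounds named here.

Of the compounds shown here, three have so far been measured in a toxicity assay on the whole organism (strain Icem-CET (SPF Caw)) for cytotoxicity, with Mus musculus as the target; a higher number here means that more compound is needed for the effect, a lower number that less compound is needed. Compound 1, `C=CCNC(=O)/C(C)=C(\C)c1cc(OC)c(OC)c(OC)c1`, gives 110 mg/kg in this assay. Compound 2, `C=CCNC(=O)/C(C)=C(/C)c1ccc(Cl)cc1`, gives 180 mg/kg and stands highest of the three numbers; its nearest neighbour is compound 3, `C/C(C(=O)NC1CC1)=C(\C)c1ccc(Cl)cc1`, which gives 170 mg/kg, and the furthest is compound 1, although both of those gaps lie within the usual scatter of repeated measurements. Among the compounds with values here, the only step between measured compounds that differ in one place, a 1.1-fold lower number from compound 2 to compound 3 (0.02 log units; within the scatter), puts cyclopropyl in place of allyl on an amide-type nitrogen and leaves the number essentially where it was.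

The step followed here leads from compound 2 to compound 4, `C=CCNC(=O)/C(C)=C(/C)c1ccc(Br)cc1`, which has not yet been measured in this assay. The change is bromo in place of chloro on an aromatic carbon. No measured step touches this position: the single step on record concerns the amide-type nitrogen and not the six-membered aromatic ring, so nothing shown bears directly on exchanging one halogen for another. With no evidence pointing up or down, the expected step is a 1.1-fold lower number from compound 2 to compound 4 (0.02 log units; within the scatter), that is, none beyond the scatter. Compound 4 is therefore estimated at 170 mg/kg, with a range from 90 mg/kg to 330 mg/kg.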

Compound 4, dose for half-maximal effect: 400 mg/kg
Compound 4: middle estimate off by 2.4-fold (0.37 log units), on the low side; measured number outside the range, above it.
By their numbers in this assay, from the lowest: compounds 1, 3 and 2 (each within the scatter of the next); then compound 4.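

In this assay the exchange on this aromatic carbon, para to a large group, gives a 2.2-fold higher number from compound 2 to compound 4 (0.35 log units; beyond the scatter) and so shows that this position responds to a swap of one halogen for another: in this pair, more compound is needed for the effect with bromo than with chloro. This is the first step on record to go beyond the scatter, whereas the change on the amide-type nitrogen, a 1.1-fold lower number from compound 2 to compound 3 (0.02 log units; within the scatter), stayed within it, so the halogen position is the one place shown so far where a single change moves the number. Nothing on hand bears on why the number moves with this exchange.

The compounds shown leave open how fluoro, iodo, methoxy or an amine on this same aromatic carbon would stand in this assay, since a single pair of halogens gives no trend. They also leave open whether bromo in place of chloro gives a similar step when cyclopropyl rather than allyl sits on the amide-type nitrogen.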